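The source may report more compounds than this note shows. Statements on the series, on what has been measured and on what is new or still open speak of the compounds shown alone.

Compound 2, with structure `CCOc1ccc2c(Cl)ccnc2c1`, gives in a functional assay on RKO cells (Homo sapiens) for cytotoxicity, read by MTT assay, with a stated time of 48 h (on this read-out lower numbers stand for stronger inhibition and higher numbers for weaker inhibition), a reading of 3870 nM. Among the compounds with values here, of the two measured compounds it carries the higher number; its only neighbour is compound 1, with structure `CC(C)COc1ccc2c(Cl)ccnc2c1`, which in this assay gives 2680 nM. Within the data shown here, the one step between them, a 1.4-fold higher number from compound 1 to compound 2 (0.16 log units; within the scatter), does not rise above the scatter.

Compound 3, with structure `CC(C)Oc1ccc2c(Cl)ccnc2c1`, is not yet measured. It differs from compound 2 by methyl in place of hydrogen on a saturated chain carbon bound to an oxygen on an aromatic ring and a saturated chain carbon, so the chain on the oxygen grows by one carbon. Among the measured compounds shown here, the only step that speaks to this change is the one from compound 1 to compound 2, where a larger branch on that same chain carbon was swapped for a smaller one, and it stayed within the scatter. Compound 3 is therefore expected to show a step of a 1.2-fold lower number from compound 2 to compound 3 (0.08 log units; within the scatter) in this assay, with no shift beyond the scatter. The estimate for compound 3 is 3200 nM, expected between 1500 nM and 7000 nM.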

Compound 3, half-maximal inhibitory concentration: 2690 nM
The estimate for compound 3 lay 1.2-fold (0.08 log units) above the measured number, and the stated range covers the measured number.
By their numbers in this assay, from the lowest: compounds 1, 3 and 2 (each within the scatter of the next).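

In this assay, a methyl in place of hydrogen on the saturated chain carbon bound to the oxygen turns ethoxy into isopropoxy and gives a 1.4-fold lower number from compound 2 to compound 3 (0.16 log units; within the scatter), so branching on this carbon, which the earlier pair did not test, leaves the number within the scatter. Isopropyl in place of isobutyl on the same oxygen gives a 1.0-fold higher number from compound 1 to compound 3 (0.00 log units; within the scatter), so ethyl, isopropyl and isobutyl on this oxygen cannot be told apart in this cell read-out. No measurement on hand offers an explanation for this flat result.

As far as these compounds go, it stays open whether a longer chain such as hexyl, a chain ending in an amine or one ending in a carboxylic acid on this oxygen would move the number beyond the scatter. The rest of the core is the same in all three compounds, so these numbers say nothing about changes there.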